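Purine-indane series: aryl replaced by alkylamino on the core

The source may report more compounds than this note shows. Statements on the series, on what has been measured and on what is new or still open speak of the compounds shown alone.

Measured compounds:
compound 1, `OC[C@H]1C[C@@H](Cn2cnc3c(-c4ccc(Cl)cc4)ncnc32)c2ccccc21`: 0.63 ug/mL
compound 2, `Cn1ncc2c1[C@H](Cn1cnc3c(Cl)nc(N)nc31)C[C@@H]2CO`: 3.2 ug/mL

In a functional assay on CCRF-CEM cells (Homo sapiens) (on this read-out higher numbers stand for weaker inhibition and lower numbers for stronger inhibition), compound 1 gives 0.63 ug/mL, the lowest of the two numbers shown. The nearest, compound 2, gives 3.2 ug/mL in this assay, a gap beyond the usual scatter, so compound 1 is the stronger inhibitor of the pair. Compound 3, `CC(C)Nc1ncnc2c1ncn2C[C@@H]1C[C@H](CO)c2ccccc21`, keeps the core of compound 1 and differs from it in one place: isopropylamino in place of 4-chlorophenyl on an aromatic carbon. For the measured compounds named here, no measured pair in the set differs in this way, so the size of such a step cannot be read from measured data, and compound 2 differs from compound 1 in too many places to help. On the structural change alone a modest weakening of inhibition is expected, with a step of a 2.4-fold higher number from compound 1 to compound 3 (0.38 log units; beyond the scatter). Compound 3 is therefore estimated at 1.5 ug/mL in this assay, with a range from 0.5 ug/mL to 5 ug/mL.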

Compound 3, half-maximal inhibitory concentration: 24 ug/mL
For compound 3 the middle estimate is 16-fold (1.20 log units) below the measured one; the whole stated range lies below it.
By their numbers in this assay, from the lowest: compound 1; then compound 2; then compound 3.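

Isopropylamino in place of 4-chlorophenyl on an aromatic carbon gives a 38-fold higher number from compound 1 to compound 3 (1.58 log units; beyond the scatter) in this assay, the first single-place change in the series. With the rest of compound 1 kept, inhibition in this cell assay therefore depends strongly on the group at this position, something the comparison of compound 1 with compound 2 could not show, as those two differ in too many places. The change removes an aromatic ring and brings in a nitrogen-linked open chain, but nothing at hand bears on which part of the swap matters.

Still open, as far as these compounds go, is whether the ring or the nitrogen link decides the outcome: an unsubstituted phenyl, a cyclohexyl or an anilino group at this carbon would separate the two. A dimethylamino group or a longer alkylamino chain would show whether the alkylamino step depends on the chain itself.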